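Swapping benzothiazole for phenyl: cytotoxicity stays out of reach

The compounds below may be only part of what the source reports. "The series", "measured", "known", "first", "only" and "open" are said of these compounds alone.

Compound 1 `O=C(Nc1ccc(-c2nc3ccccc3s2)cc1)c1cc([N+](=O)[O-])ccc1Cl` was tested in an ADME assay on HepG2 cells (Homo sapiens) for cytotoxicity, with a stated time of 72 h (on this read-out lower numbers stand for an effect already at smaller amounts and higher numbers for an effect only at larger amounts of compound), and compound 1 gives only a limit there, > 27000 nM. Compound 2 `O=C(Nc1ccc(-c2ccccc2)cc1)c1cc([N+](=O)[O-])ccc1Cl` differs from compound 1 by phenyl in place of 1,3-benzothiazol-2-yl on an aromatic carbon. In this assay compound 2 likewise reaches only a limit, > 27000 nM. The step that the two limits leave unreadable from compound 1 to compound 2 therefore cannot be read. Compound 3 `O=C(Nc1cccc(-c2nc3ccccc3s2)c1)c1cc([N+](=O)[O-])ccc1Cl` has the same atoms as compound 1 joined differently; the difference between the two cores is not broken down here. In this assay compound 3 also shows only a limit, > 27000 nM. All three results sit at the same point, (the limit of > 27000 nM in this assay, at which 3 of the 3 values shown sit). Compound 4 `O=C(Nc1cccc(-c2ccccc2)c1)c1cc([N+](=O)[O-])ccc1Cl` is not yet measured; it differs from compound 3 by phenyl in place of 1,3-benzothiazol-2-yl on an aromatic carbon. This is the same kind of change as from compound 1 to compound 2, but the place differs: para to a large group in the first pair, meta to a large group in the second. Compound 4 is expected to give 40000 nM, within a likely range from 15000 nM to 150000 nM. The step that the limit leaves unreadable from compound 3 to compound 4 is expected to be small because a step that the two limits leave unreadable from compound 1 to compound 2 stayed within the limit.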

Compound 4, half-maximal effective concentration in the HepG2 assay: > 27000 nM
Compound 4: no number, only a limit; the forecaster's own chance of this, stated with the estimate: 80%; the middle value lies beyond the limit too.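

In the HepG2 assay compound 3 gives only a limit, > 27000 nM. In the HepG2 assay compound 4 also gives only a limit, > 27000 nM. No step between compound 3 and compound 4 can be read, and the same holds for compound 1 and compound 2: the limit of > 27000 nM in the HepG2 assay, at which 4 of the 4 values shown sit.

The compounds shown leave open whether phenyl in place of 1,3-benzothiazol-2-yl changes cytotoxicity at all, since none reaches a readable number.

In a physicochemical assay for solubility, read by spectrophotometry, in phosphate buffer, measured as kinetic solubility, with a stated time of 18 h, at pH 7.4 (on this read-out higher numbers stand for higher solubility and lower numbers for lower solubility), compound 3 gives 580 nM and compound 4 gives 410 nM. In the physicochemical assay the printed step is a 1.4-fold lower number from compound 3 to compound 4 (0.15 log units; within the scatter).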